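Swapping cyclopropylmethyl for 3,3-difluorocyclobutyl

The compounds below may be only part of what the source reports. "The series", "measured", "known", "first", "only" and "open" are said of these compounds alone.

Compound 1 `FC1(F)CCC(c2nc3cnc(Nc4ccc(C(F)(F)F)cn4)cc3[nH]2)C1`: 120000 nM
Compound 2 `FC(F)(F)c1ccc(Nc2cc3[nH]c(C4CC4)nc3cn2)nc1`: < 5000 nM (a limit of the assay)
Compound 3 `FC(F)(F)c1ccc(Nc2cc3[nH]c(CC4CC4)nc3cn2)nc1`: 118000 nM

In a physicochemical assay for solubility, using the shake flask method, in phosphate buffer, measured as kinetic solubility, with a stated time of 20 h, at pH 6.5 (on this read-out lower numbers stand for lower solubility and higher numbers for higher solubility), compound 3 gives 118000 nM. Among the measured compounds shown here, that is level with the only other full number, with a 1.0-fold lower number from compound 1 to compound 3 (0.01 log units; within the scatter), and well clear of the limit, with an at least 23-fold higher number from compound 2 to compound 3 (1.37 log units; beyond the scatter).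

Compound 4 `FC1(F)CC(c2nc3cnc(Nc4ccc(C(F)(F)F)cn4)cc3[nH]2)C1` carries 3,3-difluorocyclobutyl in place of cyclopropylmethyl on an aromatic carbon. The closest measured group is the 3,3-difluorocyclopentyl of compound 1. Two measured swaps start from it: cyclopropyl gave a large step, an at least 24-fold lower number from compound 1 to compound 2 (1.38 log units; beyond the scatter), while cyclopropylmethyl gave none beyond the scatter. These two disagree, so only a modest drop in this assay is expected. The expected step is a 2.4-fold lower number from compound 3 to compound 4 (0.37 log units; beyond the scatter). For compound 4 the estimated value is 50000 nM, with an estimated range from 8000 nM to 130000 nM.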

Compound 4, solubility: 118000 nM
Compound 4: middle estimate off by 2.4-fold (0.37 log units), on the low side; the range from low to high includes it.
By their numbers in this assay, from the lowest: compounds 3, 4 and 1 (each within the scatter of the next). At a limit, below all of these: compound 2.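

In this assay, 3,3-difluorocyclobutyl joins cyclopropylmethyl and 3,3-difluorocyclopentyl as a third group at this position giving the same level, with no change at the digits printed from compound 3 to compound 4 (within the scatter) and a 1.0-fold lower number from compound 1 to compound 4 (0.01 log units; within the scatter). Cyclopropyl now stands alone among the four groups, with an at least 23-fold higher number from compound 2 to compound 4 (1.37 log units; beyond the scatter). Compound 2 carries a limit, not a full number: the limit of < 5000 nM in this assay, at which 1 of the 4 values shown sits.

The compounds shown do not explain why cyclopropyl alone departs from the others. Also open, from the compounds shown here alone, is whether plain cyclobutyl without fluorine, or an amine at this position, would stay at the same level.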